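The source may report more compounds than this note shows. Statements on the series, on what has been measured and on what is new or still open speak of the compounds shown alone.

Compound 1 `CC(C)N1CCN(Cc2csc(N)c2C(=O)c2ccc(Cl)cc2)CC1` is the starting point. In an assay on CHO cells for displacement of a labelled ligand from adenosine receptor A3 (Homo sapiens), read by scintillation counting, with a stated time of 120 min, tested at 10 uM (a lower number here means less inhibition, a higher number more inhibition at the concentration tested (going by the name of the read-out)), compound 1 gives 0%, a number level with that of compound 2 `Nc1scc(CN2CCN(c3ccc(F)cc3Cl)CC2)c1C(=O)c1ccc(Cl)cc1`, which gives 0% in this assay; these two together stand lowest of the three measured numbers. Compound 3 `Nc1scc(CN2CCN(C3CCCC3)CC2)c1C(=O)c1ccc(Cl)cc1` gives 3% in this assay, and the step of a number 3 percentage points higher from compound 1 to compound 3 (within the scatter) is within the scatter, as is no change at the digits printed from compound 1 to compound 2 (within the scatter).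

Compound 4 `Nc1scc(CN2CCN(C3CCCCCC3)CC2)c1C(=O)c1ccc(Cl)cc1` differs from compound 1 in one place: cycloheptyl in place of isopropyl on an amine nitrogen in a ring. The measured step that bears on it most closely is a number 3 percentage points higher from compound 1 to compound 3 (within the scatter), where another ring of carbon only took the place of isopropyl on the same amine nitrogen; the step of a number 3 percentage points higher from compound 2 to compound 3 (within the scatter) lies within the scatter as well. None of the three measured changes at this amine nitrogen has taken the number beyond the scatter. Compound 4 is therefore expected to give 3% in this assay, with a range from 0% to 15%. The estimated step of a number 3 percentage points higher from compound 1 to compound 4 (within the scatter) is expected to stay within the scatter.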

Compound 4, a percentage reported as inhibition, at one concentration (the size of the read-out at that concentration, not a potency): 0%
Compound 4: middle estimate off by 3 percentage points, on the high side, within the range that was stated.
By their numbers in this assay, from the lowest: compounds 1, 2, 4 and 3 (each within the scatter of the next).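

In this assay, the larger ring does what the smaller groups did: cycloheptyl, with 7 heavy atoms against the 3 of isopropyl, gives no reading that can be told from the starting compound (no change at the digits printed from compound 1 to compound 4 (within the scatter)). The two rings of carbon only also cannot be told apart (a number 3 percentage points lower from compound 3 to compound 4 (within the scatter)), and neither can cycloheptyl and 2-chloro-4-fluorophenyl (no change at the digits printed from compound 2 to compound 4 (within the scatter)), so all four groups on this amine nitrogen now lie within the scatter of one another. No measurement is at hand to explain this flat picture.

Still open, from the compounds shown here alone, is whether any group on this nitrogen can lift the number beyond the scatter, such as a carboxylic acid or a longer chain ending in a hydroxyl. Also open, going by these compounds, is whether an amide at the free amine of the shared core would move it.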